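Trimming a Ring Next to an Amide Carbonyl

This account rests on a few compounds, and the source may have more. Where it says the series, first, only, none or still open, it means among the compounds named here.

The measured compounds:
compound 1, `O=C(C1CCCCC1)N1N=CCC1c1ccccc1`, 5.9
compound 2, `CC(C)(C)C(=O)N1N=CCC1c1ccc(S(C)(=O)=O)cc1`, 4.1
compound 3, `O=C(c1cnco1)N1CCC(C(=O)N2N=CC[C@H]2c2ccccc2)CC1`, 2.7

In a physicochemical assay for lipophilicity, read by HPLC, measured as chromatographic lipophilicity, at pH 7.4 (on this read-out lower numbers stand for lower lipophilicity and higher numbers for higher lipophilicity), compound 1 stands highest of the three. Compound 2 comes nearest, its value 4.1 lying beyond the scatter below that of compound 1, and compound 3 lies furthest away, its value 2.7 further still below.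

The unmeasured compound 4, `O=C(C1CCC1)N1N=CCC1c1ccccc1`, differs from compound 1 in one place: cyclobutyl in place of cyclohexyl on a carbonyl carbon. Among the compounds with values here, no pair of measured compounds shows this change, so its effect is not known from the numbers here. A drop beyond the scatter is expected, a step of a number 0.90 log units lower from compound 1 to compound 4 (beyond the scatter). For compound 4 in this assay the estimate is 5, within a range from 4.5 to 5.5.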

Compound 4, distribution coefficient: 4.7
Beside the measured number, compound 4's estimate is 0.30 log units above it; the range from low to high includes it.
By their numbers in this assay, from the lowest: compound 3; then compound 2; then compound 4; then compound 1.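

In this assay, cyclobutyl in place of cyclohexyl on a carbonyl carbon gives a step of a number 1.20 log units lower from compound 1 to compound 4 (beyond the scatter) with the rest of the molecule unchanged. Within the data shown here, this is the first single change in the set, and it shows that this position alone can move the read-out by a large amount, which the earlier compounds, differing in several places, could not show. Nothing at hand explains the size of this step.

Going by these compounds, whether cyclopentyl on this carbonyl carbon would fall between compound 1 and compound 4 stays open. So does the effect of an amine or a carboxylic acid on the ring.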